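The source may report more compounds than this note shows. Statements on the series, on what has been measured and on what is new or still open speak of the compounds shown alone.

Measured compounds:
Compound 1 `COc1cccc(S(=O)(=O)Nc2cccc(-c3nc(-c4ccc(NC(=O)c5cccnc5)cc4Cl)no3)c2)c1` – > 10000 nM
Compound 2 `C#Cc1cccc(NC(=O)Nc2cccc(-c3nc(-c4ccc(NC(=O)c5cccnc5)cc4Cl)no3)c2)c1` – > 10000 nM

In a functional assay on MDA-MB-231 cells (Homo sapiens) for antiproliferative activity, read by MTT assay, with a stated time of 72 h (a lower number here means a stronger inhibitor, a higher number a weaker inhibitor), compound 1 gives > 10000 nM, which is a limit of the assay. In this assay compound 2 likewise gives > 10000 nM, also a limit. The step that the two limits leave unreadable from compound 1 to compound 2 is therefore unreadable, and compound 2 stands at the limit of > 10000 nM in this assay, at which 2 of the 2 values shown sit, with no number of its own. Compound 3 `CC(=O)Nc1ccc(NC(=O)Nc2cccc(-c3nc(-c4ccc(NC(=O)c5cccnc5)cc4Cl)no3)c2)cc1Br` differs from compound 2 by 4-acetamido-3-bromophenyl in place of 3-ethynylphenyl on an amide-type nitrogen. Among the compounds with values here, no measured step bears on this change, so no direction beyond the scatter can be read from it. Compound 3 is expected at 15000 nM with a range of 3000 nM to 60000 nM. The step that the limit leaves unreadable from compound 2 to compound 3 is expected to leave compound 3 at the same limit.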

Compound 3, half-maximal inhibitory concentration: 1000 nM
Estimate against measurement, compound 3: 15-fold (1.18 log units) above; measured number below the stated range.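

In this assay, within the data shown here, the change on the amide-type nitrogen gives the first readable step, with 4-acetamido-3-bromophenyl in place of 3-ethynylphenyl: an at least 10-fold lower number from compound 2 to compound 3 (1.00 log units; beyond the scatter). The group on this nitrogen therefore bears on the read-out, which the earlier step, unreadable between two limits, could not show. Compound 3 alone has a number of its own rather than a limit: the limit of > 10000 nM in this assay, at which 2 of the 3 values shown sit.

From the compounds shown here alone, the acetamido group and the bromine enter together, so their separate shares in the step remain open. Also open, going by these compounds, is whether an amine or a carboxylic acid in place of the acetamido group would hold the number of compound 3.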